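The source may hold more compounds than are shown below. What is called first, only, known or untested is meant among the compounds shown, and "the series" means these compounds.

Measured so far in an ADME assay on liver for metabolic stability, with Liver microsome (Homo sapiens) as the target, using microsomes; a higher number here means faster removal of the compound, a lower number slower removal
- compound 1 `N#Cc1ccc(C2CCN(C(=O)Nc3cc(-c4ccccn4)n[nH]3)CC2)cc1` gives 25.3 mL.min-1.g-1
- compound 2 `O=C(Nc1cc(-c2ccccn2)n[nH]1)N1CCC(c2ccccc2)CC1` gives 15.3 mL.min-1.g-1

Not yet measured: compound 3 `O=C(Nc1cc(-c2ccccn2)n[nH]1)N1CCC(Oc2ccccn2)CC1`

In this assay compound 2 at 15.3 mL.min-1.g-1 lies within the scatter of compound 1, so the pair sets no order. Within the data shown here, the one measured step is a 1.7-fold lower number from compound 1 to compound 2 (0.22 log units; within the scatter) and involves hydrogen in place of cyano on an aromatic carbon. The next change is of another kind, with (pyridin-2-yl)oxy in place of phenyl on a saturated ring carbon. Among the measured compounds shown here, no measured compound carries a different group at that saturated ring carbon, so the step to compound 3 has no direct precedent. The step between compound 1 and compound 2 offers only a rough sense of scale, and it stays within the scatter. With no evidence for a direction, no step beyond the scatter is expected in this assay, although the uncertainty is wide. The estimate therefore stays close to compound 2 at 15.3 mL.min-1.g-1 as its starting point. The estimated step is a 1.1-fold lower number from compound 2 to compound 3 (0.04 log units; within the scatter) and it serves only as a working figure. Compound 3 is expected at 14 mL.min-1.g-1 with an estimated range from 6 mL.min-1.g-1 to 32 mL.min-1.g-1 until the measurement is available.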

Compound 3, intrinsic clearance in microsomes: < 11.9 mL.min-1.g-1
Compound 3: no number, only a limit; the forecaster's own chance of this, stated with the estimate: 5%; middle value at least 1.1-fold (0.07 log units) from the limit.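

In this assay compound 3 gives < 11.9 mL.min-1.g-1, a limit of the assay and not a number: the limit of < 11.9 mL.min-1.g-1 in this assay, at which 1 of the 3 values shown sits. At the saturated ring carbon, three ring bonds from the ring nitrogen, (pyridin-2-yl)oxy in place of phenyl gives an at least 1.2-fold lower number from compound 2 to compound 3 (0.10 log units; that floor lies within the scatter), a floor that does not by itself separate the two compounds. Among these compounds, the same group in place of 4-cyanophenyl gives an at least 2.1-fold lower number from compound 1 to compound 3 (0.32 log units; beyond the scatter), the first step in these notes read as beyond the scatter and the first evidence on a change at this carbon, where the earlier step concerned only an aromatic carbon of the phenyl ring.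

The full size of both steps stays open, and the compounds shown do not separate the contribution of the oxygen that enters from that of the pyridine nitrogen. Also open, as far as these compounds go, is how a phenoxy group, a pyridin-2-yl group attached directly to the saturated ring carbon, or an amine at that carbon would read in this assay.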